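Butyl for 2,4-difluorophenyl on the sulfonyl group

This account rests on a few compounds, and the source may have more. Where it says the series, first, only, none or still open, it means among the compounds named here.

Measured in a functional assay on MCF7 cells (Homo sapiens) for antiproliferative activity, read by sulforhodamine B assay, with a stated time of 72 h (on this read-out lower numbers stand for stronger inhibition and higher numbers for weaker inhibition), as follows:
- compound 1 `CCCCS(=O)(=O)Nc1cc(-c2ccc3ncnc(NCCN(C)C)c3c2)cnc1OC` gives 3240 nM
- compound 2 `CCCCS(=O)(=O)Nc1cc(-c2ccc3ncnc(NCc4ccncc4)c3c2)cnc1OC` gives 18700 nM
- compound 3 `COc1ncc(-c2ccc3ncnc(NCCCN(C)C)c3c2)cc1NS(=O)(=O)c1ccc(F)cc1F` gives 3660 nM

Compound 3 (3660 nM) lies within the scatter of compound 1 (3240 nM), while compound 2 (18700 nM) stands clearly higher. Going to compound 4 `CCCCS(=O)(=O)Nc1cc(-c2ccc3ncnc(NCCCN(C)C)c3c2)cnc1OC` brings butyl in place of 2,4-difluorophenyl on a sulfonyl sulfur in one place, butyl in place of 2,4-difluorophenyl on a sulfonyl sulfur. Among the compounds with values here, the one measured step, a 5.8-fold higher number from compound 1 to compound 2 (0.76 log units; beyond the scatter), concerns a different place and gives no direct reading on this change. Within the data shown here, it shows only that a single change can move this series beyond the scatter. Compound 1 already carries butyl on the sulfonyl sulfur and compound 3 carries 2,4-difluorophenyl there, and their values sit within the scatter, although the two also differ in a second place. On that evidence, no step beyond the scatter is expected in this assay for this change. The expected step is a 1.0-fold lower number from compound 3 to compound 4 (0.02 log units; within the scatter) as estimated here. Compound 4 is estimated at 3500 nM with an expected range from 1400 nM to 8500 nM in this read-out.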

Compound 4, half-maximal inhibitory concentration: 4730 nM
Estimate against measurement, compound 4: 1.4-fold (0.13 log units) below; the range from low to high includes it.
By their numbers in this assay, from the lowest: compounds 1, 3 and 4 (each within the scatter of the next); then compound 2.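

In this assay, within the data shown here, a 1.3-fold higher number from compound 3 to compound 4 (0.11 log units; within the scatter) gives the first direct reading on a sulfonyl sulfur: butyl in place of 2,4-difluorophenyl stays within the scatter, so the aromatic ring is not needed here to hold this level. On the amine chain, a 1.5-fold higher number from compound 1 to compound 4 (0.16 log units; within the scatter) is also within the scatter for (dimethylamino)methyl in place of dimethylamino, whereas a 4.0-fold lower number from compound 2 to compound 4 (0.60 log units; beyond the scatter) for 2-(dimethylamino)ethyl in place of pyridin-4-yl lies beyond it. No measured property is at hand to account for these steps.

On these data alone, whether the sulfonyl sulfur stays this insensitive with a smaller group such as methyl, or with a cyclopropyl group, remains open. Also open, as far as these compounds go, is whether a morpholine at the end of the chain would match the dimethylamino chains.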